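Replacing chloro with nitro on the aromatic ring

The compounds below may be only part of what the source reports. "The series", "measured", "known", "first", "only" and "open" are said of these compounds alone.

In a functional assay on MDA-MB-231 cells (Homo sapiens) for inhibition, read by sulforhodamine B assay, with a stated time of 74 h (on this read-out lower numbers stand for stronger inhibition and higher numbers for weaker inhibition), compound 1 (`Cc1ccc(S(=O)(=O)N2C(=O)COC23C=CC(=O)C=C3)cc1`) gives 70 nM. Compound 2 (`O=C1C=CC2(C=C1)OCC(=O)N2S(=O)(=O)c1ccccc1`) reads > 10000 nM, which is a limit of the assay and not a number. Compound 3 (`O=C1C=CC2(C=C1)OCC(=O)N2S(=O)(=O)c1ccc(Cl)cc1`) gives 2800 nM, the higher of the two values that are not limits.

The next compound is compound 4 (`O=C1C=CC2(C=C1)OCC(=O)N2S(=O)(=O)c1ccc([N+](=O)[O-])cc1`), in which nitro takes the place of chloro on an aromatic carbon, para to a large group: nitro in place of chloro on an aromatic carbon.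

Within the data shown here, three measured steps bear on this change. Replacing methyl with hydrogen gave an at least 140-fold higher number from compound 1 to compound 2 (2.15 log units; beyond the scatter), and replacing methyl with chloro gave a 40-fold higher number from compound 1 to compound 3 (1.60 log units; beyond the scatter). Both are large, but both start from the methyl of compound 1, and the step now in question involves no methyl. The closer guide is the exchange without methyl, chloro for hydrogen, which gave the smaller at least 3.5-fold lower number from compound 2 to compound 3 (0.55 log units; beyond the scatter). Among the measured compounds shown here, no nitro compound has been measured, so the direction remains open, and a small change around compound 3 is expected, probably none beyond the scatter. The expected step is a 1.1-fold higher number from compound 3 to compound 4 (0.03 log units; within the scatter). For compound 4 the estimated value is 3000 nM, with an expected range of 500 nM to 10000 nM.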

Compound 4, half-maximal inhibitory concentration: > 10000 nM
Compound 4 was reported as a limit; the forecaster's own chance of this, stated with the estimate: 25%; middle value at least 3.3-fold (0.52 log units) away from the limit.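

Compound 4 shows that in this assay the position still responds to a change once methyl is gone: nitro in place of chloro gives an at least 3.5-fold higher number from compound 3 to compound 4 (0.55 log units; beyond the scatter), so the two groups are not interchangeable here. Set against methyl, nitro gives an at least 140-fold higher number from compound 1 to compound 4 (2.15 log units; beyond the scatter), which makes nitro the third group, after hydrogen and chloro, to stand far from compound 1 at this place on the aromatic ring. Among the four compounds shown, only compound 1 reaches a low number, and compound 3, though measurable, remains a long way from it.

Compound 2 and compound 4 both sit at a limit of the assay and not at a number, so the step between them cannot be read, and neither can their order: the limit of > 10000 nM in this assay, at which 2 of the 4 values shown sit.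

Going by these compounds, how far these two compounds lie past that limit stays open. So does whether the low number of compound 1 belongs to methyl alone or would also appear with an ethyl, a methoxy or an amine at the same place.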